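From Methyl to Methoxy on a Shared Core

This account rests on a few compounds, and the source may have more. Where it says the series, first, only, none or still open, it means among the compounds named here.

compound 1 `O=[N+]([O-])c1cccc(Nc2nc(SCc3ccc(C(F)(F)F)cc3)nc3ccccc23)c1`: > 50000 nM
compound 2 `Cc1ccc(Nc2nc(SCc3ccc(C(F)(F)F)cc3)nc3ccccc23)cc1`: > 50000 nM

Both measured compounds share the same core and differ only in the aryl group on the amine nitrogen. In a functional assay on MCF7 cells (Homo sapiens) for cytotoxicity, read by MTT assay, with a stated time of 72 h (on this read-out higher numbers stand for weaker inhibition and lower numbers for stronger inhibition), compound 1 gives > 50000 nM, which is a limit of the assay and not a number. In this assay compound 2 also gives > 50000 nM, again a limit. The step that the two limits leave unreadable from compound 1 to compound 2 is therefore not readable. Compound 2 stands at the limit of > 50000 nM in this assay, at which 2 of the 2 values shown sit, so no number is known for it, only that its inhibition is weaker than the assay can resolve.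

Compound 3 `COc1ccc(Nc2nc(SCc3ccc(C(F)(F)F)cc3)nc3ccccc23)cc1` takes the change (methoxy in place of methyl on an aromatic carbon). For the measured compounds named here, the only measured step, from compound 1 to compound 2, bears on this change in the loosest sense, as another swap of the group on the same aryl ring, and its size could not be read. With no readable step to build on, no direction can be expected, and the step that the limit leaves unreadable from compound 2 to compound 3 is an estimate without measured support. Compound 3 is expected at 60000 nM, within 15000 nM to 250000 nM, most likely reported again only as a limit.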

Compound 3, half-maximal inhibitory concentration: 47200 nM
Estimate against measurement, compound 3: 1.3-fold (0.10 log units) above; the range from low to high includes it.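

Compound 3 is the only compound shown that gives a number and not a limit in this assay, so with 4-methoxyphenyl on the amine nitrogen the shared core reaches the readable range. Methoxy in place of methyl on the aromatic carbon gives an at least 1.0-fold lower number from compound 2 to compound 3 (0.02 log units; that floor lies within the scatter), and the exchange of the whole aryl group gives an at least 1.0-fold lower number from compound 1 to compound 3 (0.02 log units; that floor lies within the scatter); both are only floors, as neither starting compound has a number, so neither step on its own shows a difference beyond the scatter. The result therefore places this change at the edge of what the assay can read and does not establish a clear effect of the methoxy group, and the other two compounds stay at the ceiling: the limit of > 50000 nM in this assay, at which 2 of the 3 values shown sit.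

What the compounds leave open is whether another group in the same place on the ring, such as a hydroxyl, an amine or a longer chain like ethoxy, would bring the number well clear of that limit. They also leave open how far compound 2 truly lies from compound 3, since only one of the two has a number.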